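Solubility of a cyclopropylmethylamino analogue of compound 2

The compounds below may be only part of what the source reports. "The series", "measured", "known", "first", "only" and "open" are said of these compounds alone.

Measured compounds:
compound 1 `C[C@@H]1CN(c2c(C#N)c(C(F)(F)F)nn2-c2ccc(S(C)(=O)=O)cc2)[C@H](C)CO1` — in a physicochemical assay for solubility (a higher number here means a more soluble compound, a lower number a less soluble compound), compound 1 gives "not determined" (no result reported)
compound 2 `C[C@@H]1CN(c2c(C#N)c(C(F)F)nn2-c2ccc(S(C)(=O)=O)cc2)[C@H](C)CO1` — 50 ug/mL

Two compounds have been examined in this assay. For compound 1 the result is "not determined" (no result reported), so nothing can be said of it. Going by the values given here, compound 2 is therefore the only compound with a recorded value, and in this assay compound 2 gives 50 ug/mL. Among the compounds with values here, with no second number, no step between measured compounds can be drawn, and compound 2 stands alone as the single reference point.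

Compound 3 `CS(=O)(=O)c1ccc(-n2nc(C(F)F)c(C#N)c2NCC2CC2)cc1` is the next compound to be measured. It differs from compound 2 in one place: a group of 5 heavy atoms (4 carbon, 1 nitrogen; one three-membered non-aromatic ring of carbon only) in place of a group of 8 heavy atoms (6 carbon, 1 nitrogen, 1 oxygen; one six-membered non-aromatic ring with 2 hetero atoms), on an aromatic carbon

Within the data shown here, there is no measured pair that resembles this change, so the size of the step rests on the change itself. Because compound 2 gives 50 ug/mL and the group that enters is smaller than the group that leaves, a modest step is expected, most likely downward but possibly not beyond the usual scatter. Compound 3 is thus expected to show 35 ug/mL in this assay, within a range from 10 ug/mL to 120 ug/mL. The step of a 1.4-fold lower number from compound 2 to compound 3 (0.15 log units; within the scatter) that this estimate means is expected to be small.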

Compound 3, solubility: > 200 ug/mL
Compound 3 was reported as a limit; the forecaster's own chance of this, stated with the estimate: 5%; middle value at least 5.7-fold (0.75 log units) away from the limit.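

In this assay, putting (cyclopropylmethyl)amino in place of the six-membered non-aromatic ring with 2 hetero atoms, on the same aromatic carbon of the five-membered aromatic ring, goes with an at least 4.0-fold higher number from compound 2 to compound 3 (0.60 log units; beyond the scatter). Going by these compounds alone, the earlier compounds offered a single number and no step, so this is the first indication that the read-out responds to what stands at this position, and that the response to this change lies beyond the usual scatter. The value for compound 3 is a limit of the assay and not a number, so the step has a lower bound but no known size: the limit of > 200 ug/mL in this assay, at which 1 of the 3 values shown sits.

The change alters several things at once, including the ring, the hydrogen-bond donor count and the 2 defined stereocentres, so these two compounds leave open which of them goes with the step, and whether a dimethylamino group, with no donor on its nitrogen, or an ethylamino chain, with no ring, would behave like the (cyclopropylmethyl)amino group. Any step involving compound 1 cannot be read, so the comparison of trifluoromethyl with difluoromethyl also stays open.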